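The source may hold more compounds than are shown below. What is called first, only, known or untested is meant among the compounds shown, and "the series" means these compounds.

Compound 1 `CCOC(=O)c1sc(-c2cccc(NC(=O)c3ccc(Cl)cc3)c2)nc1Nc1ccc(N2CCN(C)CC2)cc1` was tested in a functional assay on Ramos cells (Homo sapiens) for antiproliferative activity, read by CCK-8 assay, with a stated time of 72 h, tested at 40 uM (a higher number here means more inhibition at the concentration tested (going by the name of the read-out), a lower number less inhibition), where compound 1 gives 46.9%. Compound 2 `CCOC(=O)c1sc(-c2cccc(NC(=O)c3ccc(F)c(Cl)c3)c2)nc1Nc1ccc(N2CCN(C)CC2)cc1` carries the change (3-chloro-4-fluorophenyl in place of 4-chlorophenyl on a carbonyl carbon); in this assay compound 2 gives 72.5%, a step of a number 25.6 percentage points higher from compound 1 to compound 2 (beyond the scatter). Compound 3 `CN1CCN(c2ccc(Nc3nc(-c4cccc(NC(=O)c5ccc(Cl)cc5)c4)sc3C(N)=O)cc2)CC1` differs from compound 1 in its core by amino in place of ethoxy on a carbonyl carbon, and in this assay compound 3 gives 99%, a step of a number 52.1 percentage points higher from compound 1 to compound 3 (beyond the scatter). Compound 3 thus stands highest of the three measured compounds, with its steps to both others beyond the scatter.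

Compound 4 `CN1CCN(c2ccc(Nc3nc(-c4cccc(NC(=O)c5ccc(F)c(Cl)c5)c4)sc3C(N)=O)cc2)CC1` has not yet been measured. It differs from compound 3 by 3-chloro-4-fluorophenyl in place of 4-chlorophenyl on a carbonyl carbon, the same change as that from compound 1 to compound 2, made twice among these compounds, the place being identical word for word. That earlier step was modest, but it was made on a core that differs by amino in place of ethoxy on a carbonyl carbon. A much smaller step is expected here because compound 3 already gives 99%, leaving little room upward; the expected step is a number 1 percentage points lower from compound 3 to compound 4 (within the scatter). Compound 4 is estimated at 98% in this assay, expected to lie between 92% and 100%.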

Compound 4, a percentage reported as inhibition, at one concentration (the size of the read-out at that concentration, not a potency): 97.5%
Compound 4: middle estimate off by 0.5 percentage points, on the high side, and the stated range covers the measured number.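

In this assay, 3-chloro-4-fluorophenyl in place of 4-chlorophenyl on a carbonyl carbon gives a step of a number 1.5 percentage points lower from compound 3 to compound 4 (within the scatter), so the change did not carry over at the same size from the core of compound 1 to the core of compound 3: the same change on two cores in this assay, a number 25.6 percentage points higher (beyond the scatter) from compound 1 to compound 2 and a number 1.5 percentage points lower (within the scatter) from compound 3 to compound 4, 27.1 percentage points apart, beyond the scatter of two such steps

Read the other way, amino in place of ethoxy on a carbonyl carbon gives a step of a number 25 percentage points higher from compound 2 to compound 4 (beyond the scatter), so that change also differs in size between the two partner groups: the same change on two cores in this assay, a number 52.1 percentage points higher (beyond the scatter) from compound 1 to compound 3 and a number 25 percentage points higher (beyond the scatter) from compound 2 to compound 4, 27.1 percentage points apart, beyond the scatter of two such steps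

Compound 3 gives 99% and compound 4 gives 97.5%, both close to the top of a percentage read at a single concentration, so this does not show that the aryl change would be without effect on this core at a lower concentration.

Going by these compounds, how compound 3 and compound 4 compare at lower concentrations remains open. Also open, on these data alone, is how a carboxylic acid or a methylamino group in place of ethoxy on the carbonyl carbon would behave in this assay.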